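Replacing the 3,4-dimethoxyphenyl group of compound 1

The compounds below may be only part of what the source reports. "The series", "measured", "known", "first", "only" and "open" are said of these compounds alone.

Compound 1 `COc1ccc(-c2ccc(-c3ccc(-c4nc5cc(C)ccc5[nH]4)cc3)cc2)cc1OC` gives 2190 nM
Compound 2 `COc1cc(-c2ccc(-c3ccc(-c4nc5cc(C)ccc5[nH]4)cc3)cc2)cc(OC)c1OC` gives 2110 nM
Compound 3 `COc1ccc(-c2ccc(-c3ccc(-c4nc5ccccc5[nH]4)cc3)cc2)cc1OC` gives 9250 nM

In a functional assay on KB cells (Homo sapiens) for inhibition, read by sulforhodamine B assay (a lower number here means a stronger inhibitor of growth, a higher number a weaker inhibitor of growth), compound 1 stands with compound 2 at the lower end of the three numbers, while compound 3 stands apart. Compound 4 `Cc1ccc2[nH]c(-c3ccc(-c4ccc(-c5ccc(O)cc5)cc4)cc3)nc2c1` is still unmeasured. It carries 4-hydroxyphenyl in place of 3,4-dimethoxyphenyl on an aromatic carbon. The closest measured step alters the same group: a 1.0-fold lower number from compound 1 to compound 2 (0.02 log units; within the scatter). The other step, a 4.2-fold higher number from compound 1 to compound 3 (0.63 log units; beyond the scatter), swaps methyl for hydrogen and leaves this group untouched. Among the measured compounds shown here, no measured compound carries 4-hydroxyphenyl, so the evidence is thin, and only a small change is expected, within or near the scatter. The expected step is a 1.1-fold higher number from compound 1 to compound 4 (0.04 log units; within the scatter). The estimate for compound 4 is 2400 nM, with an expected range from 800 nM to 7000 nM.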

Compound 4, concentration for 50% growth inhibition: 21200 nM
The estimate for compound 4 lay 8.8-fold (0.95 log units) below the measured number, outside the stated range (above it).
By their numbers in this assay, from the lowest: compounds 2 and 1 (each within the scatter of the next); then compound 3; then compound 4.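

In this assay, this position proved sensitive to the group it carries: 4-hydroxyphenyl in place of 3,4-dimethoxyphenyl gave a 9.7-fold higher number from compound 1 to compound 4 (0.99 log units; beyond the scatter), whereas the earlier change on the same ring, a 1.0-fold lower number from compound 1 to compound 2 (0.02 log units; within the scatter), stayed within the scatter. Growth inhibition therefore tolerated an added methoxy but weakened with this replacement. Nothing available explains the weakening.

The swap removes both methoxy groups and adds a hydroxyl at once, so their separate contributions remain unresolved. A single methoxy or an amine at this place could help to separate them.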